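From 4-cyanophenyl to benzyl on an amide-type nitrogen

The source may report more compounds than this note shows. Statements on the series, on what has been measured and on what is new or still open speak of the compounds shown alone.

For the measured compounds named here, in a functional assay on MCF7 cells (Homo sapiens) for inhibition, read by MTT assay, with a stated time of 72 h (on this read-out lower numbers stand for stronger inhibition and higher numbers for weaker inhibition), compound 1 (`O=C(Nc1cccc(F)c1)C1CCN(C/C=C/c2ccccc2)CC1`) gives 33000 nM and compound 2 (`N#Cc1ccc(NC(=O)C2CCN(C/C=C/c3ccccc3)CC2)cc1`) gives 44500 nM in the same test, so compound 2 stands within the scatter of the only other number available. Going by the values given here, the one measured step (a 1.3-fold higher number from compound 1 to compound 2 (0.13 log units; within the scatter)) put 4-cyanophenyl in place of 3-fluorophenyl on an amide-type nitrogen. Compound 3 (`O=C(NCc1ccccc1)C1CCN(C/C=C/c2ccccc2)CC1`) changes that same place again (benzyl in place of 4-cyanophenyl on an amide-type nitrogen): benzyl in place of 4-cyanophenyl on an amide-type nitrogen. Benzyl differs from both groups measured so far, and a single step is thin evidence, so this step offers only a loose guide. That swap (a 1.3-fold higher number from compound 1 to compound 2 (0.13 log units; within the scatter)) stayed within the scatter, and so no shift beyond the scatter is expected in this assay in either direction. The estimated change (a 1.3-fold lower number from compound 2 to compound 3 (0.10 log units; within the scatter)) is correspondingly small. Compound 3 is expected at about 35000 nM within a deliberately wide estimated range from 12000 nM to 90000 nM in this test.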

Compound 3, half-maximal inhibitory concentration: > 100000 nM
Compound 3: a limit, no number; the forecaster's own chance of this, stated with the estimate: 15%; at least 2.8-fold (0.45 log units) between middle value and limit.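

Until now, swapping 3-fluorophenyl for 4-cyanophenyl on the amide-type nitrogen had stayed within the scatter, which made this position look tolerant of change in this assay. Benzyl is the first group here to move the result beyond the scatter, giving an at least 2.2-fold higher number from compound 2 to compound 3 (0.35 log units; beyond the scatter) and also an at least 3.0-fold higher number from compound 1 to compound 3 (0.48 log units; beyond the scatter), so inhibition is weaker against both earlier compounds and the position is not indifferent to every group placed on it. The value for compound 3 is a limit of the assay and not a number: the limit of > 100000 nM in this assay, at which 1 of the 3 values shown sits.

How much weaker compound 3 really is stays open, and the three groups shown cannot separate the effect of the ring's substituents from the effect of the carbon that benzyl places on the amide-type nitrogen. An unsubstituted phenyl group on that nitrogen, or a longer chain such as phenethyl, would help tell these apart, and would show whether the drop belongs to benzyl alone or to any group of this kind.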